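One Aryl Exchange Carried Over to a Second Core

A few compounds are considered here, and "the series" means these few. Any claim that something is new, unique, unknown or untested is made for them only; others in the source may bear on it.

Measured so far:
compound 1, `C#Cc1cccc(Nc2ncnc3cc(NC(=O)/C=C/c4ccccc4)sc23)c1`: 15400 nM
compound 2, `O=C(/C=C/c1ccccc1)Nc1cc2ncnc(Nc3cc(Cl)cc(Cl)c3)c2s1`: 10700 nM
compound 3, `C#Cc1cccc(Nc2ncnc3sc(NC(=O)/C=C/c4ccccc4)cc23)c1`: 58100 nM

These three were tested in a functional assay on HepG2 cells (Homo sapiens) for antiproliferative activity, read by MTT assay, with a stated time of 48 h; on this read-out lower numbers stand for stronger inhibition and higher numbers for weaker inhibition. Compound 1 and compound 3 are built from the same atoms joined differently; how the two cores differ is not broken down here. Compound 3 gives the highest number of the three, and its gaps to compound 1 and to compound 2 both lie beyond the scatter. From compound 1 to compound 2 the change is 3,5-dichlorophenyl in place of 3-ethynylphenyl on a nitrogen on an aromatic ring, and it brought a 1.4-fold lower number from compound 1 to compound 2 (0.16 log units; within the scatter). The same change, (3,5-dichlorophenyl in place of 3-ethynylphenyl on a nitrogen on an aromatic ring), turns compound 3 into compound 4, `O=C(/C=C/c1ccccc1)Nc1cc2c(Nc3cc(Cl)cc(Cl)c3)ncnc2s1`, which has not yet been measured in this assay. Because the step of a 1.4-fold lower number from compound 1 to compound 2 (0.16 log units; within the scatter) stayed within the scatter, the analogous step is expected to be small as well: a 1.3-fold lower number from compound 3 to compound 4 (0.11 log units; within the scatter). Compound 4 is therefore estimated at 45000 nM, with a likely range from 20000 nM to 110000 nM.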

Compound 4, half-maximal inhibitory concentration: 21800 nM
The estimate for compound 4 lay 2.1-fold (0.31 log units) above the measured number; the range from low to high includes it.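

In this assay, 3,5-dichlorophenyl in place of 3-ethynylphenyl gave a 2.7-fold lower number from compound 3 to compound 4 (0.43 log units; beyond the scatter). Set beside the step on the other core, this one cannot be told apart from it: the same change on two cores in this assay, a 1.4-fold lower number (0.16 log units; within the scatter) from compound 1 to compound 2 and a 2.7-fold lower number (0.43 log units; beyond the scatter) from compound 3 to compound 4, 1.9-fold (0.27 log units) apart, within the scatter of two such steps. The two cores are thus consistent with a change that carries over at a comparable size, but each core rests on a single pair, and two cores say nothing about how the change would behave on a third.

The compounds shown leave open what a plain phenyl or a 3-chlorophenyl on that nitrogen would give on either core. They also leave open whether the exchange would hold with an amine on the phenyl ring of the amide chain.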